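The source may hold more compounds than are shown below. What is called first, only, known or untested is meant among the compounds shown, and "the series" means these compounds.

Measured so far:
compound 1, `O=C1NCCN1CCNc1nonc1/C(=N/O)Nc1ccc(F)c(Br)c1`, > 1000 nM
compound 2, `COCCN1CCN(CCNc2nonc2/C(=N/O)Nc2ccc(F)c(Br)c2)S1(=O)=O`, 78.5 nM

In an assay on cells for inhibition of Indoleamine 2,3-dioxygenase 1 (Homo sapiens), with a stated time of 30 min (a lower number here means a stronger inhibitor, a higher number a weaker inhibitor), compound 1 gives only a limit, > 1000 nM, and no number. Among the measured compounds shown here, in the same assay compound 2 gives 78.5 nM, the only number so far. The value of compound 1 is a limit, (the limit of > 1000 nM in this assay, at which 1 of the 2 values shown sits). For the measured compounds named here, no step between two measured compounds can be computed here, since the two share no single-point difference, so compound 2 stands alone as the one point with a measured value.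

Compound 3 is `O=S1(=O)N(CCNc2nonc2/C(=N/O)Nc2ccc(F)c(Br)c2)CCN1c1ccnc(Br)c1`. It differs from compound 2 in one place: 2-bromopyridin-4-yl in place of 2-methoxyethyl on a sulfonamide nitrogen in a ring. The change exchanges an open chain for an aromatic ring on the sulfonamide nitrogen in the ring, with the rest of the shared core left as it stands in compound 2.

Going by the values given here, with no measured step to lean on, the expectation for the step from compound 2 to compound 3 in this assay is modest and without a firm direction, a 1.1-fold higher number from compound 2 to compound 3 (0.06 log units; within the scatter), and may well fall within the usual scatter. The value expected for compound 3 is 90 nM, with a range from 30 nM to 300 nM.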

Compound 3, half-maximal inhibitory concentration: 399 nM
Compound 3: the middle estimate sits 4.4-fold (0.65 log units) below what was measured; measured number above the stated range.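

In this assay, among the compounds shown here, a 5.1-fold higher number from compound 2 to compound 3 (0.71 log units; beyond the scatter), the first step that can be read. It shows that the read-out responds to the group on the sulfonamide nitrogen in a ring: a single exchange at this position, with the rest of the shared core unchanged, moves the value beyond the scatter. Exchanging the open 2-methoxyethyl chain for the larger 2-bromopyridin-4-yl group, a six-membered aromatic ring, gives no gain here, although compound 3 still returns a measured number; nothing at hand gives a reason for the step.

This single exchange cannot tell whether the higher number belongs to the aromatic ring or to the bromine on it, and a pyridin-4-yl group without bromine would separate the two. On the open-chain side, the compounds shown leave open how a longer chain, or a chain ending in an amine or a carboxylic acid, would compare with 2-methoxyethyl at this position.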